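Amide to urea on the anilide arm of compound 2

This account rests on a few compounds, and the source may have more. Where it says the series, first, only, none or still open, it means among the compounds named here.

Compound 2 `COc1cc(-c2nn(-c3cccc(NC(=O)c4cccc(C(F)(F)F)c4)c3)cc2-c2ccncc2)ccc1Cl` stands highest of the three numbers recorded in a functional assay on BT-549 cells (Homo sapiens) for inhibition, read by sulforhodamine B assay, with a stated time of 48 h; on this read-out higher numbers stand for weaker inhibition of growth and lower numbers for stronger inhibition of growth; compound 2 gives 2870 nM. Its nearest neighbour is compound 1 `COc1cc(-c2nn(-c3cccc(NC(=O)Nc4cc(C(F)(F)F)cc(C(F)(F)F)c4)c3)cc2-c2ccncc2)ccc1Cl`, which in this assay gives 1210 nM; furthest is compound 3 `O=C(Nc1cccc(-n2cc(-c3ccncc3)c(-c3ccc(Cl)c(O)c3)n2)c1)Nc1cc(C(F)(F)F)cc(C(F)(F)F)c1`, which gives 1090 nM. For the measured compounds named here, the only single-point step measured, a 1.1-fold lower number from compound 1 to compound 3 (0.05 log units; within the scatter), concerns the oxygen on the chlorinated ring and does not touch the anilide arm.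

Compound 4 `COc1cc(-c2nn(-c3cccc(NC(=O)Nc4ccc(Cl)c(C(F)(F)F)c4)c3)cc2-c2ccncc2)ccc1Cl` is not yet measured. The change from compound 2 to compound 4 is (4-chloro-3-(trifluoromethyl)phenyl)amino in place of 3-(trifluoromethyl)phenyl on a carbonyl carbon. Going by the values given here, no measured pair isolates this change. Compound 1 and compound 2 differ in two places at once, the amide-to-urea link and the substitution on the outer ring, and the two values show the urea of compound 1 sitting well below the amide of compound 2. Compound 3 carries the same urea and lands close to compound 1. Since the aryl group entering in compound 4 keeps one trifluoromethyl and adds a chlorine rather than a second trifluoromethyl, compound 4 is expected to move toward the ureas, with a step of a 2.2-fold lower number from compound 2 to compound 4 (0.34 log units; beyond the scatter). For compound 4 in this assay the estimate is 1300 nM, expected to fall between 600 nM and 2800 nM.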

Compound 4, concentration for 50% growth inhibition: 2360 nM
Compound 4: middle estimate off by 1.8-fold (0.26 log units), on the low side, within the range that was stated.
By their numbers in this assay, from the lowest: compounds 3, 1, 4 and 2 (each within the scatter of the next, the first and the last beyond it).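

In this assay, the change on the carbonyl carbon, a 1.2-fold lower number from compound 2 to compound 4 (0.08 log units; within the scatter), shows that (4-chloro-3-(trifluoromethyl)phenyl)amino and 3-(trifluoromethyl)phenyl cannot be told apart at this place, so a urea link here does not by itself give a number beyond the scatter of the amide. Among the ureas, compound 1 gives 1210 nM and compound 4 gives 2360 nM, two values within the scatter of each other, which means that exchanging the outer aryl group of the urea has not separated these two compounds either. No measurement at hand offers an explanation for this flat response.

The nitrogen and the chlorine enter together in compound 4, so their separate contributions remain unresolved, and either could be offset by the other. Also open, on these data alone, is whether a basic amine or a carboxylic acid on the outer ring, or a nitrile in place of the chlorine, would move the number at this place beyond the scatter.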